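Swapping the Styryl Arm for a Methylphenyl Ring

A few compounds are considered here, and "the series" means these few. Any claim that something is new, unique, unknown or untested is made for them only; others in the source may bear on it.

Compound 1 `COC(=O)/C=C/c1cccc(N(Cc2ccc(/C=C/c3ccccc3F)cc2)C(=O)C2CCCCC2)c1` is the reference point here. For the measured compounds named here, in an assay on isolated protein with Bile acid receptor (Homo sapiens) as the target (on this read-out higher numbers stand for an effect only at larger amounts of compound and lower numbers for an effect already at smaller amounts), compound 1 gives 64 nM, the lowest of the three numbers measured so far. Compound 2 `COC(=O)/C=C/c1cccc(N(Cc2ccc(/C=C/c3ccccc3F)cc2)C(=O)NC(C)C)c1` gives 431 nM in this assay, and compound 3 `COC(=O)/C=C/c1cccc(N(Cc2ccc(-c3cccc(Cl)c3)cc2)C(=O)C(C)C)c1` gives 77 nM, a number within the usual scatter of that of compound 1. Going by the values given here, the only single-site step among the measured compounds, a 6.7-fold higher number from compound 1 to compound 2 (0.83 log units; beyond the scatter), concerns the group on the carbonyl carbon and therefore does not speak to the change examined now. Compound 4 `COC(=O)/C=C/c1cccc(N(Cc2ccc(-c3cccc(C)c3)cc2)C(=O)C2CCCCC2)c1` differs from compound 1 by 3-methylphenyl in place of 2-(2-fluorophenyl)ethenyl on an aromatic carbon. Among the compounds with values here, no measured pair isolates this change, so the only hint is that compound 3 and compound 1 lie close together in this assay. On that slim basis, no step beyond the scatter is expected, with the estimated step of a 1.3-fold higher number from compound 1 to compound 4 (0.12 log units; within the scatter) leaning slightly weaker. Compound 4 is therefore expected to give about 85 nM, most likely between 30 nM and 250 nM.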

Compound 4, half-maximal effective concentration: 109 nM
Estimate against measurement, compound 4: 1.3-fold (0.11 log units) below, within the range that was stated.
By their numbers in this assay, from the lowest: compounds 1, 3 and 4 (each within the scatter of the next); then compound 2.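

The swap at this aromatic carbon, para to a large group, takes out the 2-(2-fluorophenyl)ethenyl arm with its double bond and fluorine and puts in the smaller 3-methylphenyl, and in this assay it gives a 1.7-fold higher number from compound 1 to compound 4 (0.23 log units; within the scatter) with the rest of the molecule unchanged. For the compounds shown here, this is the first direct reading at this position, as the earlier single-site step concerned only the group on the carbonyl carbon. It shows that, in this pair, neither the double bond outside the rings nor the fluorine is needed to keep the number within the scatter of compound 1, and no measurement on hand explains this result.

Going by these compounds, the fluorine and the double bond leave together here, so the contribution of each alone remains unknown. Also open, on these data alone, is how this position would respond to a group of another kind, such as an aminophenyl or a carboxylic acid on the ring, or a longer chain.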